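The compounds below may be only part of what the source reports. "The series", "measured", "known", "first", "only" and "open" are said of these compounds alone.

Measured so far in a functional assay on the whole organism (strain albino Sprague-Dawley) with Rattus norvegicus as the target, in the maximal electroshock model; a lower number here means that less compound is needed, a higher number that more compound is needed for the effect:
compound 1, `CC(C)(C)[C@@H](N)C(=O)NCc1ccc(Cl)cc1`, gives 30 mg/kg
compound 2, `CC(C)[C@@H](N)C(=O)NCc1ccc(COc2cccc(F)c2)cc1`, gives < 30 mg/kg, a limit of the assay
compound 3, `Cc1ccc(CNC(=O)[C@H](N)C(C)C)cc1`, gives 50 mg/kg

Compound 3 gives the larger of the two numbers in this assay, but compound 1, with a different side chain and a different ring substituent, gives 30 mg/kg, and the two lie within the scatter of each other. For compound 2 the assay reports only a limit, < 30 mg/kg. Among the compounds with values here, the single measured step, an at least 1.6-fold higher number from compound 2 to compound 3 (0.22 log units; that floor lies within the scatter), is the only guide, and its floor lies within the scatter; one value here sits at the limit of < 30 mg/kg in this assay, at which 1 of the 3 values shown sits.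

Compound 4, `CC(C)[C@@H](N)C(=O)NCc1ccc(OC(F)(F)F)cc1`, is reached by a change (trifluoromethoxy in place of methyl on an aromatic carbon). Within the data shown here, no measured step exchanges a methyl for a trifluoromethoxy on the ring. The step from compound 2 to compound 3 concerns a different group on a chain carbon, and compound 1 with its own ring substituent stays close to compound 3. A shift no larger than the scatter is therefore expected in this assay, a 1.7-fold lower number from compound 3 to compound 4 (0.22 log units; within the scatter), leaning if anything toward a lower number. Compound 4 is estimated at 30 mg/kg, with a range from 12 mg/kg to 80 mg/kg.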

Compound 4, dose for half-maximal effect: 18 mg/kg
Compound 4: middle estimate off by 1.7-fold (0.22 log units), on the high side; the range from low to high includes it.
By their numbers in this assay, from the lowest: compounds 4, 1 and 3 (each within the scatter of the next, the first and the last beyond it).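

Within the data shown here, the step of a 2.8-fold lower number from compound 3 to compound 4 (0.44 log units; beyond the scatter) is the first in this assay that falls beyond the scatter, and it is the first measured change made directly on an aromatic carbon of the six-membered aromatic ring of carbon only. Among these compounds, until now the sole step concerned a group on a saturated chain carbon, and its floor lay within the scatter, so the earlier compounds could not show whether this ring carbon, para to a group of 9 heavy atoms, has any bearing on the dose needed. Compound 4 shows that it does: exchanging a methyl of 1 heavy atom for a trifluoromethoxy of 5 heavy atoms, which brings in 1 hydrogen-bond acceptor, goes with less compound being needed, although this single pair gives no cause for the step.

As far as these compounds go, whether a methoxy or a trifluoromethyl group in the same place, on the core of compound 3, would give a step of like size stays open. The value of compound 2 cannot be placed against compound 4 because it is only a limit of the assay: the limit of < 30 mg/kg in this assay, at which 1 of the 4 values shown sits.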